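The source may hold more compounds than are shown below. What is called first, only, known or untested is meant among the compounds shown, and "the series" means these compounds.

Measured compounds:
compound 1, `COc1ccc(C(c2ccccc2O)c2cccc3ccccc23)c(OC)c1OC`: 13600 nM
compound 2, `COc1ccc(/C(=N/O)c2cccc3ccccc23)c(OC)c1OC`: 13100 nM

In a functional assay on A549 cells (Homo sapiens) for inhibition, read by sulforhodamine B assay, with a stated time of 48 h (on this read-out lower numbers stand for stronger inhibition and higher numbers for weaker inhibition), compound 1 gives 13600 nM, and it stands alongside compound 2, which at 13100 nM lies within the usual scatter of that number, so the two cannot be separated. Compound 3, `COc1ccc(C(c2ccc(OCCO)cc2)c2cccc3ccccc23)c(OC)c1OC`, has not yet been measured. It differs from compound 1 by 4-(2-hydroxyethoxy)phenyl in place of 2-hydroxyphenyl on a saturated chain carbon bound to two aromatic carbons. Going by the values given here, no measured pair shows this change, so in this assay the expected step from compound 1 to compound 3 is a 1.1-fold lower number from compound 1 to compound 3 (0.05 log units; within the scatter), small and in no clear direction beyond the scatter. Compound 3 is therefore estimated at 12000 nM, within 4000 nM to 40000 nM.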

Compound 3, half-maximal inhibitory concentration: > 20000 nM
Compound 3: no number, only a limit (the forecaster's own chance of this, stated with the estimate: 10%); middle value at least 1.6-fold (0.22 log units) away from the limit.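

Placing 4-(2-hydroxyethoxy)phenyl in place of 2-hydroxyphenyl on a saturated chain carbon bound to two aromatic carbons gives an at least 1.4-fold higher number from compound 1 to compound 3 (0.16 log units; that floor lies within the scatter). Going by these compounds alone, this is the first view of a change at this place, and it shows no gain in inhibition in this assay. The reading for compound 3 is a limit and not a number, so the real size of the step is unknown: the limit of > 20000 nM in this assay, at which 1 of the 3 values shown sits.

The compounds shown leave open whether removing 2-hydroxyphenyl or adding 4-(2-hydroxyethoxy)phenyl matters more. They also leave open how a 4-aminophenyl group would read at this place.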